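Ethyl for Fluoro on the Amide Aryl Ring

A few compounds are considered here, and "the series" means these few. Any claim that something is new, unique, unknown or untested is made for them only; others in the source may bear on it.

Compound 1 `CCN1CCN(c2cc(C)c3cc(NC(=O)c4ccc(F)cc4)ccc3n2)CC1` carries a 4-fluorophenyl on its carbonyl carbon. In a functional assay on SK-BR-3 cells (Homo sapiens) for antiproliferative activity, read by MTT assay, with a stated time of 72 h (on this read-out higher numbers stand for weaker inhibition and lower numbers for stronger inhibition), compound 1 gives 19800 nM, the highest of the three numbers measured. Compound 2 `CCN1CCN(c2cc(C)c3cc(NC(=O)c4ccc(C)cc4)ccc3n2)CC1` gives 11400 nM, and compound 3 `CCN1CCN(c2cc(C)c3cc(NC(=O)c4cc5ccccc5[nH]4)ccc3n2)CC1` gives 2550 nM. Compound 4 `CCc1ccc(C(=O)Nc2ccc3nc(N4CCN(CC)CC4)cc(C)c3c2)cc1` differs from compound 1 in one place: ethyl in place of fluoro on an aromatic carbon. The closest guide is the change a 1.7-fold lower number from compound 1 to compound 2 (0.24 log units; within the scatter), which stayed within the scatter. The larger changes, a 7.8-fold lower number from compound 1 to compound 3 (0.89 log units; beyond the scatter) and a 4.5-fold lower number from compound 2 to compound 3 (0.65 log units; beyond the scatter), swap the whole aryl group for 1H-indol-2-yl and bear less directly. A step of similar size to that from compound 1 to compound 2 is therefore expected, toward a lower number or none beyond the scatter. Compound 4 is estimated at 12000 nM, between 5000 nM and 30000 nM, an expected step of a 1.7-fold lower number from compound 1 to compound 4 (0.22 log units; within the scatter).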

Compound 4, half-maximal inhibitory concentration: 9850 nM
The estimate for compound 4 lay 1.2-fold (0.09 log units) above the measured number; measured number inside the range.
By their numbers in this assay, from the lowest: compound 3; then compounds 4, 2 and 1 (each within the scatter of the next).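

Ethyl in place of fluoro gives a 2.0-fold lower number from compound 1 to compound 4 (0.30 log units; within the scatter) in this assay, and the one-carbon extension from methyl to ethyl gives a 1.2-fold lower number from compound 2 to compound 4 (0.06 log units; within the scatter) on the same read-out, so fluoro, methyl and ethyl at this place on the ring remain unseparated. Replacing 1H-indol-2-yl with 4-ethylphenyl gives a 3.9-fold higher number from compound 3 to compound 4 (0.59 log units; beyond the scatter) and shows that ethyl does not close the gap to the indole amide. No measured evidence accounts for these steps. A longer chain such as propyl, or an amine or a carboxylic acid at this place, remains an open test of whether this position can move the number beyond the scatter.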